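The source may hold more compounds than are shown below. What is called first, only, known or untested is meant among the compounds shown, and "the series" means these compounds.

Measured compounds:
- compound 1 `Clc1ccc2c(NCCCNc3nc(NC4CCCCC4)nc(N4CCCCC4)n3)ccnc2c1` — 8300 nM
- compound 2 `Clc1ccc2cc(NCCNc3nc(Cl)nc(Nc4ccccc4)n3)cnc2c1` — 30500 nM

In an ADME assay on HepG2 cells (Homo sapiens) for cytotoxicity (a higher number here means a weaker inhibitor, a lower number a stronger inhibitor), compound 2 gives 30500 nM, the highest of the two numbers recorded; compound 1 gives 8300 nM, and the gap between them lies beyond the scatter. Among the measured compounds shown here, the two compounds differ in core, linker and substituents at once, so no single-point step is available.

Compound 3 `Clc1ccc2cc(NCCNc3nc(Nc4ccccc4)nc(Nc4ccccc4)n3)cnc2c1` is not yet measured. It follows from compound 2 by one change: anilino in place of chloro on an aromatic carbon. For the measured compounds named here, no measured pair isolates this change, so the expected step in this assay is small and carries a wide range. Compound 1, which carries amine substituents throughout and gives 8300 nM, points weakly toward a lower number. The step expected in this assay is a 1.5-fold lower number from compound 2 to compound 3 (0.18 log units; within the scatter). Compound 3 is estimated at 20000 nM, within a range from 7000 nM to 60000 nM.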

Compound 3, half-maximal inhibitory concentration: 3900 nM
Beside the measured number, compound 3's estimate is 5.1-fold (0.71 log units) above it, outside the stated range (below it).
By their numbers in this assay, from the lowest: compound 3; then compound 1; then compound 2.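

Anilino in place of chloro on the aromatic carbon between two ring nitrogen atoms gives a 7.8-fold lower number from compound 2 to compound 3 (0.89 log units; beyond the scatter) in this assay and is so far the only single-place step in the series. This carbon is therefore not a silent position: the substituent on it alone moves the cytotoxicity read-out beyond the scatter, toward stronger inhibition, and the change leaves a second anilino group on the same ring. Nothing available explains the size or direction of this step.

Going by these compounds, whether the step comes from the aromatic ring of the anilino group or from its nitrogen stays open, and a plain amino group or a methoxy group on this carbon would separate the two. Also open, on these data alone, is whether a fluoro-substituted anilino group or a morpholino group on this carbon would move the number further, or whether the step carries over to a longer chain in the linker.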